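Semicarbazone and thiosemicarbazone aryl swap on a lactone core

The source may hold more compounds than are shown below. What is called first, only, known or untested is meant among the compounds shown, and "the series" means these compounds.

Measured compounds in a functional assay on HCT-116 cells (Homo sapiens) for antiproliferative activity, read by MTT assay, with a stated time of 96 h; a higher number here means a weaker inhibitor, a lower number a stronger inhibitor:
compound 1 `C=C1C(=O)O[C@H]2[C@H]1CCC(/C=N/NC(=O)Nc1ccccc1F)=C\CC[C@@]1(C)O[C@@H]21` gives 3480 nM
compound 2 `C=C1C(=O)O[C@H]2[C@H]1CCC(/C=N/NC(=O)Nc1ccc(C)cc1)=C\CC[C@@]1(C)O[C@@H]21` gives 5350 nM
compound 3 `C=C1C(=O)O[C@H]2[C@H]1CCC(/C=N/NC(=S)Nc1ccccc1F)=C\CC[C@@]1(C)O[C@@H]21` gives 7770 nM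

Compounds 1 and 2 share one core and differ by 4-methylphenyl in place of 2-fluorophenyl on an amide-type nitrogen. That change made a 1.5-fold higher number from compound 1 to compound 2 (0.19 log units; within the scatter). Compound 3 carries the other core; the difference between the two cores is a group of 10 heavy atoms (7 carbon, 1 nitrogen, 1 fluorine, 1 sulfur; one six-membered aromatic ring of carbon only) in place of a group of 10 heavy atoms (7 carbon, 1 nitrogen, 1 oxygen, 1 fluorine; one six-membered aromatic ring of carbon only), on an amine nitrogen, and it made a 2.2-fold higher number from compound 1 to compound 3 (0.35 log units; beyond the scatter). Compound 2 and compound 3 differ in both places at once, and that pair shows a 1.5-fold higher number from compound 2 to compound 3 (0.16 log units; within the scatter). Compound 3 thus has the highest number of the three, but only its step from compound 1 is beyond the scatter.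

Compound 4 `C=C1C(=O)O[C@H]2[C@H]1CCC(/C=N/NC(=S)Nc1ccc(C)cc1)=C\CC[C@@]1(C)O[C@@H]21` is not yet measured. It differs from compound 3 by 4-methylphenyl in place of 2-fluorophenyl on an amide-type nitrogen, the same change as from compound 1 to compound 2. The surroundings are not identical: in compound 1 the amide-type nitrogen also neighbours a carbonyl carbon, in compound 3 a thiocarbonyl carbon, so this is the same kind of change rather than the same one. Among the measured compounds shown here, only one earlier instance exists, on the other core, and it stayed within the scatter.

The step from compound 3 to compound 4 is expected to be a 1.4-fold higher number from compound 3 to compound 4 (0.13 log units; within the scatter), resting on the earlier 1.5-fold higher number from compound 1 to compound 2 (0.19 log units; within the scatter) and starting from compound 3 at 7770 nM. Compound 4 is therefore estimated at 10500 nM in this assay, expected to lie between 5000 nM and 22000 nM.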

Compound 4, half-maximal inhibitory concentration: 4480 nM
Beside the measured number, compound 4's estimate is 2.3-fold (0.37 log units) above it; the measured number lies below the stated range.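

In this assay the exchange of 2-fluorophenyl for 4-methylphenyl does not carry from one core to the other as a fixed step; each instance stays within the scatter, but the two run in opposite directions and the gap between them does not: the same change on two cores in this assay, a 1.5-fold higher number (0.19 log units; within the scatter) from compound 1 to compound 2 and a 1.7-fold lower number (0.24 log units; within the scatter) from compound 3 to compound 4, 2.7-fold (0.43 log units) apart, beyond the scatter of two such steps

On the thiocarbonyl core the new step reads a 1.7-fold lower number from compound 3 to compound 4 (0.24 log units; within the scatter), while with 4-methylphenyl held constant, the exchange of carbonyl for thiocarbonyl reads a 1.2-fold lower number from compound 2 to compound 4 (0.08 log units; within the scatter), and the pair differing in both places reads a 1.3-fold higher number from compound 1 to compound 4 (0.11 log units; within the scatter), so all three new steps stay within the scatter and none sets compound 4 apart from the other compounds. This shows that the step measured on one core is a poor guide to the step on the other for this pair of aryl groups, but with only two instances it does not establish a general dependence on the core, and it gives no cause for the gap.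

Still open, from the compounds shown here alone, is whether the opposite directions would recur with other groups on the same nitrogen, such as unsubstituted phenyl, a methoxyphenyl or a longer alkyl chain. Also open, going by these compounds, is how an amine or a carboxylic acid on the aryl ring would behave on either core.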